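A small aryl swap with little data behind it

A few compounds are considered here, and "the series" means these few. Any claim that something is new, unique, unknown or untested is made for them only; others in the source may bear on it.

Readings so far in a physicochemical assay for permeability, using PAMPA; a higher number here means that the compound crosses the layer faster, a lower number that the compound crosses the layer more slowly
Compound 1 `Cc1oc(-c2c(Cl)cccc2Cl)nc1CN1CCC(C(=O)NCCCN2C[C@H](C)C[C@H](C)C2)CC1`: "not determined" (no result reported)
Compound 2 `Cc1ccccc1-c1nc(CN2CCC(C(=O)N3CCN(C4CCN(C)CC4)CC3)CC2)c(C)o1`: < 3.2 10^-6 cm/s (a limit, not a number)

Compound 1 has no place on the scale yet, as no result was reported for it in this assay and the shared core therefore has little measured support. Compound 3 `COc1cccc(Br)c1-c1nc(CN2CCC(C(=O)NCCCN3C[C@H](C)C[C@H](C)C3)CC2)c(C)o1` is still to be measured. The structural change is 2-bromo-6-methoxyphenyl in place of 2,6-dichlorophenyl on an aromatic carbon and puts 2-bromo-6-methoxyphenyl in place of 2,6-dichlorophenyl on an aromatic carbon. One six-membered aromatic ring of carbon only stays in that position, and neither group carries a net charge.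

With no number for compound 1, the size of this step cannot be read from the data. For this exchange, no step beyond the usual scatter is expected in this assay in either direction. The only anchor for the expectation is compound 2 with < 3.2 10^-6 cm/s as its reading, again a limit of the assay, so the estimate stays close to that mark. Compound 3 is estimated at 3.5 10^-6 cm/s (expected range 1 10^-6 cm/s to 12 10^-6 cm/s).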

Compound 3, apparent permeability: 245 10^-6 cm/s
Compound 3: the middle estimate sits 70-fold (1.85 log units) below what was measured, outside the stated range (above it).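

In this assay, for the compounds shown here, compound 3 reads 245 10^-6 cm/s, while compound 1 has the entry "not determined" (no result reported), so no step between compound 1 and compound 3 can be read. The compounds shown leave open how much of this reading, if any, comes from having 2-bromo-6-methoxyphenyl in place of 2,6-dichlorophenyl.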